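Cytotoxicity notes: chloro entering the anilide of compound 2

The source may hold more compounds than are shown below. What is called first, only, known or untested is meant among the compounds shown, and "the series" means these compounds.

Measured in an ADME assay on HepG2 cells (Homo sapiens) for cytotoxicity, read by trypan blue exclusion, with a stated time of 48 h, in the presence of a further agent that is not named here; a higher number here means that more compound is tolerated, a lower number that less compound is tolerated:
compound 1, `c1ccc(Cn2cnc3c(-c4ccco4)nccc32)cc1`: > 25000 nM
compound 2, `COc1ccc2nc(C)cc(OCC(=O)Nc3ccccc3)c2c1`: > 155000 nM
compound 3, `COc1cc(NC(=O)COc2cc(C)nc3ccc(OC)cc23)cc(OC)c1`: > 131000 nM

All three readings in this assay are limits of the assay, not numbers. Compound 1 sits at the limit of > 25000 nM in this assay, at which 1 of the 3 values shown sits, a limit. Compound 2 stands at the limit of > 155000 nM in this assay, at which 1 of the 3 values shown sits, a limit, and the two further values shown for the series are limits as well. Compound 3 sits at the limit of > 131000 nM in this assay, at which 1 of the 3 values shown sits, also a limit. No two of these compounds differ in a single place, so no measured step exists, and the readings of compound 2 and compound 3 show only that each stays at its own limit.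

Compound 4 is `COc1ccc2nc(C)cc(OCC(=O)Nc3ccccc3Cl)c2c1`, not yet measured. From compound 2 the change is chloro in place of hydrogen on an aromatic carbon, ortho to a large group, so that phenyl becomes 2-chlorophenyl and anilino becomes (2-chlorophenyl)amino. Among the compounds with values here, no measured step guides the size of this change. In this assay the expectation is for no step beyond the scatter. Compound 4 is estimated at 150000 nM, with a range from 40000 nM to 300000 nM. This estimate means a step of an at least 1.0-fold lower number from compound 2 to compound 4 (0.01 log units; that floor lies within the scatter), expected to lie within the scatter, and the reading is expected most likely to come back as a limit rather than a number.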

Compound 4, half-maximal cytotoxic concentration: > 140000 nM
Compound 4 ended at the assay's limit; the forecaster's own chance of this, stated with the estimate: 80%; the middle value is on the limit's open side.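

In this assay compound 4 gives > 140000 nM, a limit of the assay and not a number. Compound 2 gives > 155000 nM, also a limit, and the step from one to the other for chloro in place of hydrogen cannot be read. The compounds shown leave open the half-maximal cytotoxic concentration of each compound.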